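The source may report more compounds than this note shows. Statements on the series, on what has been measured and on what is new or still open speak of the compounds shown alone.

Measured compounds:
compound 1, `O=C(COc1cccc2ccccc12)N/N=C/c1cccc(O)c1`, 32.6 ug/mL;
compound 2, `O=C(COc1cccc2ccccc12)N/N=C/c1ccc([N+](=O)[O-])cc1`, 87.9 ug/mL;
compound 3, `O=C(COc1cccc2ccccc12)N/N=C/c1cccc(Br)c1`, 87.4 ug/mL.

All three numbers come from an ADME assay on MT4 cells (Homo sapiens) for cytotoxicity, read by MTT assay, with a stated time of 4 days; a lower number here means that less compound is tolerated, a higher number that more compound is tolerated. Compound 3 and compound 2 lie within the scatter of each other, and both stand beyond the scatter above compound 1, which gives 32.6 ug/mL. Among the compounds with values here, the one step between measured compounds that differ in a single place is a 2.7-fold higher number from compound 1 to compound 3 (0.43 log units; beyond the scatter), a hydroxy-bearing compound tolerated less than its bromo counterpart.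

Compound 4, `COc1ccc(/C=N/NC(=O)COc2cccc3ccccc23)cc1`, differs from compound 3 in one place: 4-methoxyphenyl in place of 3-bromophenyl on a carbon with a double bond to nitrogen. Within the data shown here, no measured pair exchanges bromo for methoxy, so the only guidance is that the nitro and bromo compounds sit together while the hydroxy compound sits lower, and the methoxy group brings no hydrogen-bond donor. Compound 4 is therefore expected to stay close to compound 3, with a 1.2-fold lower number from compound 3 to compound 4 (0.07 log units; within the scatter) judged within the scatter. Compound 4 is estimated at 75 ug/mL, with a range from 35 ug/mL to 160 ug/mL in this assay.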

Compound 4, half-maximal cytotoxic concentration: 76.9 ug/mL
Compound 4: middle estimate off by 1.0-fold (0.01 log units), on the low side; measured number inside the range.
By their numbers in this assay, from the lowest: compound 1; then compounds 4, 3 and 2 (each within the scatter of the next).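

In this assay, 4-methoxyphenyl in place of 3-bromophenyl on a carbon with a double bond to nitrogen leaves the number within the scatter (a 1.1-fold lower number from compound 3 to compound 4 (0.06 log units; within the scatter)), even though the entering group carries a hydrogen-bond acceptor and the leaving group none, and methoxy in place of nitro also stays within it (a 1.1-fold lower number from compound 2 to compound 4 (0.06 log units; within the scatter)). Among these four compounds, methoxy, bromo and nitro therefore stand together, while the hydroxy compound, compound 1, stands apart (a 2.4-fold higher number from compound 1 to compound 4 (0.37 log units; beyond the scatter)). Nothing available explains this separation.

Because the step to compound 4 changes both the group and its place on the ring, the two effects cannot be separated. From the compounds shown here alone, whether an amine or a carboxylic acid on this ring would stand with the hydroxy compound or with the other three remains open.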